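Trading methoxy for trifluoromethyl in a positive allosteric modulator

This account rests on a few compounds, and the source may have more. Where it says the series, first, only, none or still open, it means among the compounds named here.

Of the compounds shown here, three sharing a core have been measured, and a fourth awaits measurement. In a functional assay on cells for positive allosteric modulation of metabotropic glutamate receptor 2 (Homo sapiens), read by fluorescence and calcium flux, with a stated time of 30 min (a lower number here means that less compound is needed, a higher number that more compound is needed for the effect), compound 1 `FC(F)(F)c1cc(Br)c2nnn(CC3CC3)c2c1` gives 140 nM, compound 2 `COc1cc(Br)c2nnn(CC3CC3)c2c1` gives 730 nM, and compound 3 `COc1cccc2c1nnn2CC1CC1` gives 400 nM. Compound 1 and compound 2 differ in one place, (trifluoromethyl in place of methoxy on an aromatic carbon), and this change produced a 5.2-fold lower number from compound 2 to compound 1 (0.72 log units; beyond the scatter). Compound 3 and compound 2 differ by more than a single group, and the difference between their two cores is not broken down here.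

Compound 4 `FC(F)(F)c1cccc2c1nnn2CC1CC1` is the unmeasured one. It differs from compound 3 as trifluoromethyl in place of methoxy on an aromatic carbon. This is the same kind of change as that from compound 2 to compound 1, though the surroundings are not identical: in compound 2 the group sits meta to a bromo group, meta to a fused ring and para to a fused ring, whereas in compound 3 it sits ortho to a fused ring and meta to a fused ring. Because compound 2 to compound 1 gave a 5.2-fold lower number from compound 2 to compound 1 (0.72 log units; beyond the scatter), a step of similar direction but somewhat tempered size is expected for compound 4, namely a 3.1-fold lower number from compound 3 to compound 4 (0.49 log units; beyond the scatter), with some uncertainty since the step was seen only once. The estimate for compound 4 in this assay is therefore 130 nM, expected to fall between 50 nM and 350 nM.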

Compound 4, half-maximal effective concentration: 148 nM
The estimate for compound 4 lay 1.1-fold (0.06 log units) below the measured number, and the stated range covers the measured number.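

Putting trifluoromethyl in place of methoxy again lowered the number in this assay, with a 2.7-fold lower number from compound 3 to compound 4 (0.43 log units; beyond the scatter). Set beside the earlier case, the change points the same way on both cores, and the two steps cannot be told apart in size: the same change on two cores in this assay, a 5.2-fold lower number (0.72 log units; beyond the scatter) from compound 2 to compound 1 and a 2.7-fold lower number (0.43 log units; beyond the scatter) from compound 3 to compound 4, 1.9-fold (0.29 log units) apart, within the scatter of two such steps. So within this small set the change carried over from one core to the other in direction and, as far as the scatter allows, in size, but two pairs cannot show that it would hold on a further core, and they do not explain why the number falls.

The compounds shown leave open whether other groups at the same place, such as a nitrile, a methyl group or a longer chain, would lower the number as far as trifluoromethyl does. Going by these compounds, it is also open whether the change would still carry over on a core that bears an amine or a carboxylic acid elsewhere.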